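The compounds below may be only part of what the source reports. "The series", "measured", "known", "first", "only" and "open" are said of these compounds alone.

Measured compounds:
compound 1 `Cc1ccccc1N(C)C(=O)c1ccc(-c2ccc(OS(N)(=O)=O)cc2)o1` — 31 nM
compound 2 `Cc1cc(-c2ccc(C(=O)N(C)c3ccccc3C)o2)ccc1OS(N)(=O)=O` — "nd" (no result reported)

Going by the values given here, in an assay on T47D cells for inhibition of Steryl-sulfatase (Homo sapiens), read by HPLC, with a stated time of 24 h (on this read-out lower numbers stand for stronger inhibition and higher numbers for weaker inhibition), compound 1 gives 31 nM, the only number that the series shows; compound 2 has no reported result. Compound 3 `Cc1ccccc1N(C)C(=O)c1ccc(-c2ccc(OS(N)(=O)=O)cc2F)o1` keeps the core of compound 1 and differs from it in one place: fluoro in place of hydrogen on an aromatic carbon. Among the compounds with values here, with no step between measured compounds available, the expectation rests on the single value of compound 1. Such a small change is expected to move the read-out little, giving compound 3 an estimated step of a 1.2-fold lower number from compound 1 to compound 3 (0.09 log units; within the scatter), within the usual scatter. Compound 3 is therefore expected to give about 25 nM, in a range from 8 nM to 80 nM.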

Compound 3, half-maximal inhibitory concentration: 16 nM
For compound 3 the middle estimate is 1.6-fold (0.19 log units) above the measured one, within the range that was stated.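

In this assay, a 1.9-fold lower number from compound 1 to compound 3 (0.29 log units; within the scatter) shows that this aromatic carbon, ortho to a large group and meta to a sulfamoyloxy group, accepts fluoro in place of hydrogen with no change beyond the scatter. This is one step at one position, so it describes only this replacement. No evidence at hand bears on the reason for this result. The compounds shown leave open how chloro, methoxy or trifluoromethyl would behave on the same carbon, and whether fluoro on other carbons of this ring would give a similar result.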